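Series notes: fluoro step from compound 2 to compound 4

This account rests on a few compounds, and the source may have more. Where it says the series, first, only, none or still open, it means among the compounds named here.

Measured so far in a functional assay on U-87MG ATCC cells (Homo sapiens) for antiproliferative activity, read by MTT assay, with a stated time of 48 h; on this read-out lower numbers stand for stronger inhibition and higher numbers for weaker inhibition:
- compound 1 `O=C(/C=C\Nc1ccc(O)cc1)c1cn(-c2ccccc2)nc1-c1ccccc1` gives 4290 nM
- compound 2 `COc1ccc(N/C=C\C(=O)c2cn(-c3ccccc3)nc2-c2ccccc2)cc1` gives only a limit of this assay, > 50000 nM
- compound 3 `COc1cc(N/C=C\C(=O)c2cn(-c3ccccc3)nc2-c2ccccc2)cc(OC)c1OC` gives 2350 nM

Compound 2 stands at the limit of this assay; no number is known for it beyond that, and among the values shown one sits at that limit (the limit of > 50000 nM in this assay, at which 1 of the 3 values shown sits). Among the measured compounds shown here, the single recorded step, an at least 11-fold higher number from compound 1 to compound 2 (1.06 log units; beyond the scatter), concerns a different change and gives no guide to a fluoro step. Compound 4 `COc1ccc(N/C=C\C(=O)c2cn(-c3ccccc3)nc2-c2ccc(F)cc2)cc1` differs from compound 2 by fluoro in place of hydrogen on an aromatic carbon. For the measured compounds named here, no measured step bears on this change, so no step beyond the usual scatter is expected in this assay, and a limit may again be reported. For compound 4 the estimate is 50000 nM, with a range of 10000 nM to 200000 nM. The implied step, a number no higher from compound 2 to compound 4 (the limit leaves the size open), is expected to stay within the scatter.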

Compound 4, half-maximal inhibitory concentration: 2500 nM
Compound 4: the middle estimate sits 20-fold (1.30 log units) above what was measured, and the stated range ends above it.
By their numbers in this assay, from the lowest: compounds 3, 4 and 1 (each within the scatter of the next). At a limit, above all of these: compound 2.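

In this assay, the change from phenyl to 4-fluorophenyl gives an at least 20-fold lower number from compound 2 to compound 4 (1.30 log units; beyond the scatter), so a single fluoro on this ring, a site not varied among compounds 1 to 3, can by itself shift the read-out beyond the scatter. Compound 2 gives a limit and not a number, so the true size of the step stays open: the limit of > 50000 nM in this assay, at which 1 of the 4 values shown sits.

Still open, as far as these compounds go, is whether chloro or an amine in the same place would give a comparable step. Also open, from the compounds shown here alone, is whether fluoro there would shift the read-out alongside the hydroxy of compound 1 or the three methoxy groups of compound 3.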